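The source may report more compounds than this note shows. Statements on the series, on what has been measured and on what is new or still open speak of the compounds shown alone.

Working notes on the series. In an ADME assay on MT4 cells (Homo sapiens) for cytotoxicity (on this read-out lower numbers stand for higher toxicity in this test and higher numbers for lower toxicity in this test), compound 1 `Cc1cccc(S(=O)(=O)n2c(=O)[nH]c3ccc(Cl)cc32)c1` reads > 307000 nM. That value is a limit of the assay and not a number.

Compound 2 `Cc1ccc(S(=O)(=O)n2c(=O)[nH]c3ccc(Cl)cc32)cc1` gives 134000 nM, the higher of the two actual numbers in the set, and compound 3 `Cc1ccc(S(=O)(=O)n2c(=O)[nH]c3ccc(Cl)cc32)c(C)c1` gives 39300 nM.

The next structure is compound 4 `Cc1ccc(S(=O)(=O)n2c(=O)[nH]c3ccc(Cl)cc32)cc1C`. Its difference from compound 2 is methyl in place of hydrogen on an aromatic carbon, ortho to a methyl group and meta to a large group.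

Among the measured compounds shown here, two measured steps bear on this change. The closest is the same kind of replacement on compound 2 at another place on the ring, which gave a 3.4-fold lower number from compound 2 to compound 3 (0.53 log units; beyond the scatter). The other, 4-methylphenyl in place of 3-methylphenyl on the sulfonyl sulfur, gave an at least 2.2-fold lower number from compound 1 to compound 2 (0.36 log units; beyond the scatter) and shows that the place of a methyl can matter in this assay, though its size is bounded only on one side.

For the measured compounds named here, a modest move to a lower number is therefore expected, somewhat smaller than the one seen for compound 3 , with the new methyl at a different place. The expected step is a 2.2-fold lower number from compound 2 to compound 4 (0.35 log units; beyond the scatter). For compound 4 the estimated value is 60000 nM. The expected range for compound 4 runs from 25000 nM to 140000 nM.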

Compound 4, half-maximal cytotoxic concentration: > 371000 nM
Compound 4: no number, only a limit; the forecaster's own chance of this, stated with the estimate: 10%; middle value at least 6.1-fold (0.79 log units) from the limit.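

In this assay compound 4 gives a limit of the assay and not a number: the limit of > 371000 nM in this assay, at which 1 of the 4 values shown sits.

Methyl in place of hydrogen on an aromatic carbon, ortho to a methyl group and meta to a large group, gives an at least 2.7-fold higher number from compound 2 to compound 4 (0.44 log units; beyond the scatter), whereas the same replacement at the other place on the ring gave a 3.4-fold lower number from compound 2 to compound 3 (0.53 log units; beyond the scatter). Among the compounds shown here, the two steps from compound 2 therefore run in opposite directions, so in this small set the direction of the change depends on where the new methyl sits, which the earlier compounds alone did not show.

As far as these compounds go, compound 1 and compound 4 both stand as limits, and the step between them cannot be read, so the order of these two compounds stays open, as does how far the true value of compound 4 lies from its limit. The compounds shown also leave open whether another group at this place, such as ethyl, methoxy, an amine or a carboxylic acid, would keep the reading at a limit or bring it back to a measurable number.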